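The compounds below may be only part of what the source reports. "The series", "measured", "known", "first", "only" and "open" are said of these compounds alone.

In a functional assay on P388 cells (Mus musculus) for cytotoxicity (a lower number here means a stronger inhibitor, a higher number a weaker inhibitor), three compounds on a shared core differ only in one group on an aromatic carbon. Compound 1 `Cc1cc(-c2c(F)cc3c(=O)c(Cc4ccccc4O)cn(C4CC4)c3c2F)cc(C)n1`, which carries hydroxy, gives 670 nM. Compound 2 `COc1ccccc1Cc1cn(C2CC2)c2c(F)c(-c3cc(C)nc(C)c3)c(F)cc2c1=O`, its methyl ether, gives 37000 nM. Compound 3 `Cc1cc(-c2c(F)cc3c(=O)c(Cc4ccccc4N)cn(C4CC4)c3c2F)cc(C)n1`, which carries amino, gives 2100 nM, the second highest of the three numbers and nearer to the value of compound 1 than to that of compound 2. Amino in place of hydroxy produces a 3.1-fold higher number from compound 1 to compound 3 (0.50 log units; beyond the scatter), while amino in place of methoxy produces an 18-fold lower number from compound 2 to compound 3 (1.25 log units; beyond the scatter). Methyl in place of hydrogen on the oxygen produces a 55-fold higher number from compound 1 to compound 2 (1.74 log units; beyond the scatter).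

Compound 4 `Cc1cc(-c2c(F)cc3c(=O)c(Cc4c[nH]cn4)cn(C4CC4)c3c2F)cc(C)n1` makes a wider change: 1H-imidazol-4-yl in place of 2-aminophenyl on a saturated chain carbon bound to an aromatic carbon. That is, 1H-imidazol-4-yl stands in place of 2-aminophenyl on a saturated chain carbon bound to an aromatic carbon. Going by the values given here, no measured step replaces the whole ring, so the three steps bear on this change only indirectly. They show that single exchanges on that ring can range from modest, as in a 3.1-fold higher number from compound 1 to compound 3 (0.50 log units; beyond the scatter), to large, as in a 55-fold higher number from compound 1 to compound 2 (1.74 log units; beyond the scatter). A modest rise is therefore expected, with wide uncertainty, and the estimated change is a 2.9-fold higher number from compound 3 to compound 4 (0.46 log units; beyond the scatter). For compound 4 the expected value is 6000 nM, with an estimated range from 1200 nM to 30000 nM.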

Compound 4, half-maximal inhibitory concentration: 390 nM
Compound 4: the middle estimate sits 15-fold (1.19 log units) above what was measured; measured number outside the range, below it.
By their numbers in this assay, from the lowest: compounds 4 and 1 (each within the scatter of the next); then compound 3; then compound 2.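

Every earlier step in this assay changed only a group on the aromatic ring, and compound 4 shows that the ring itself can be exchanged on the saturated chain carbon: 1H-imidazol-4-yl in place of 2-aminophenyl brings a 5.4-fold lower number from compound 3 to compound 4 (0.73 log units; beyond the scatter) and in place of 2-methoxyphenyl brings a 95-fold lower number from compound 2 to compound 4 (1.98 log units; beyond the scatter) as the larger of the two steps. In place of 2-hydroxyphenyl it brings a 1.7-fold lower number from compound 1 to compound 4 (0.24 log units; within the scatter) and so leaves the number level with that of the hydroxy compound, which means that among these compounds a six-membered aromatic ring of carbon only is not needed for a number of this size. The lowest group of numbers thus holds two compounds with quite different rings, one carrying hydroxy and the other a five-membered aromatic ring with 2 hetero atoms.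

From the compounds shown here alone, what a pyridyl ring or an unsubstituted phenyl would give on the same carbon, and whether a methyl on an imidazole nitrogen or a longer chain to the imidazole would keep the number, stays open. Nothing measured here speaks to what lies behind these steps.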